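A few compounds are considered here, and "the series" means these few. Any claim that something is new, unique, unknown or untested is made for them only; others in the source may bear on it.

Compound 1 `O=C(Nc1cccc(-c2ccco2)c1)C1CCCN(C(=O)c2cc(C(F)(F)F)cc(C(F)(F)F)c2)C1` gives 0% in an ADME assay on PC-3 cells (Homo sapiens) for cytotoxicity, read by WST assay, tested at 100 uM; a lower number here means less inhibition, a higher number more inhibition at the concentration tested (going by the name of the read-out). Compound 2 `O=C(Nc1cccc(Oc2ccccn2)c1)C1CCCN(C(=O)c2cc(C(F)(F)F)cc(C(F)(F)F)c2)C1` gives 0% in this assay. Compound 3 `O=C(Nc1cccc(OCCc2ccccn2)c1)C1CCCN(C(=O)c2cc(C(F)(F)F)cc(C(F)(F)F)c2)C1` gives 5% in this assay.

All three numbers sit within the scatter of one another. Compound 3 is separated from compound 1 by a number 5 percentage points higher from compound 1 to compound 3 (within the scatter) and from compound 2 by a number 5 percentage points higher from compound 2 to compound 3 (within the scatter), so none of the three can be told apart in this assay, and all are close to the bottom of the scale.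

Compound 4 `COC(=O)c1cccc(NC(=O)C2CCCN(C(=O)c3cc(C(F)(F)F)cc(C(F)(F)F)c3)C2)c1` differs from compound 3 by methoxycarbonyl in place of 2-(pyridin-2-yl)ethoxy on an aromatic carbon. The same position on the aromatic ring was already varied among the measured compounds: the steps of no change at the digits printed from compound 1 to compound 2 (within the scatter) and a number 5 percentage points higher from compound 1 to compound 3 (within the scatter) exchanged groups at this place without moving the read-out beyond the scatter. Nothing measured suggests that a methoxycarbonyl group at this position behaves differently, so no step beyond the scatter is expected in this assay in either direction. The expected step is a number 2 percentage points lower from compound 3 to compound 4 (within the scatter). Compound 4 is therefore estimated to give 3% in this assay, with a range from 0% to 12%.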

Compound 4, a percentage reported as inhibition, at one concentration (the size of the read-out at that concentration, not a potency): 0%
Compound 4: the middle estimate sits 3 percentage points above what was measured; low and high end bracket the measured number.
By their numbers in this assay, from the lowest: compounds 1, 2, 4 and 3 (each within the scatter of the next).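

Methoxycarbonyl brings something new to this aromatic carbon: it has no ring and only 4 heavy atoms, where 2-(pyridin-2-yl)ethoxy has 9, yet in this assay the steps read a number 5 percentage points lower from compound 3 to compound 4 (within the scatter) and no change at the digits printed from compound 2 to compound 4 (within the scatter) and no change at the digits printed from compound 1 to compound 4 (within the scatter) with none of them leaving the scatter. A group without a ring therefore cannot be told apart here from the three groups that carry one, and all four compounds stay close to the bottom of the scale. No outside measurement bears on why the read-out stays this flat.

Going by these compounds, whether an amine or a carboxylic acid on this aromatic carbon would also stay within the scatter remains open. So does whether any group at this place, or any change elsewhere on the shared core, can lift the number clearly off the bottom of the scale.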